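This account rests on a few compounds, and the source may have more. Where it says the series, first, only, none or still open, it means among the compounds named here.

In an ADME assay on HEK293 cells (Homo sapiens) for cytotoxicity, with a stated time of 72 h (a higher number here means that more compound is needed for the effect, a lower number that less compound is needed), compound 2 `Cc1cc(NC(=O)Nc2ccc(N(C)C)cc2)c2ccccc2n1` gives > 25000 nM, which is a limit of the assay and not a number. Compound 1 `Cc1cc(NC(=O)Nc2ccc(F)c(F)c2)c2ccccc2n1` gives > 25000 nM, which is also a limit. Taken together, the series so far shows (the limit of > 25000 nM in this assay, at which 2 of the 3 values shown sit). Compound 3 `Cc1cc(NC(=O)Nc2ccc(F)cc2F)c2ccccc2n1` is the only one of the three with a number, at 10000 nM. Compound 2 therefore has no exact position in the series, and only its limit can be compared with the other values.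

The next compound is compound 4 `Cc1cc(NC(=O)Nc2ccc(C(=O)O)cc2)c2ccccc2n1`, which carries carboxy in place of dimethylamino on an aromatic carbon, para to a large group (carboxy in place of dimethylamino on an aromatic carbon). Going by the values given here, no pair of measured compounds differs in one place, so the series offers no direct precedent for the size of this change.

The expectation rests on compound 2 with its limit of > 25000 nM. The expected step of a number no higher from compound 2 to compound 4 (the limit leaves the size open) is none beyond the usual scatter of this assay, with no direction favoured. Another report of a limit rather than a number is thought more likely than not. For compound 4 the estimated value is 25000 nM, with an expected range from 12000 nM to 50000 nM.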

Compound 4, half-maximal effective concentration: > 25000 nM
Compound 4 gave a limit, no number; the forecaster's own chance of this, stated with the estimate: 70%; the middle value lies on the limit itself.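

No step from compound 2 to compound 4 can be read, because both results are limits and not numbers: the limit of > 25000 nM in this assay, at which 3 of the 4 values shown sit.

The compounds shown leave open whether carboxy in place of dimethylamino on an aromatic carbon shifts the value in this assay at all, and by how much.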